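A few compounds are considered here, and "the series" means these few. Any claim that something is new, unique, unknown or untested is made for them only; others in the source may bear on it.

In a functional assay on NCI-H460 cells (Homo sapiens) for inhibition, read by sulforhodamine B assay, with a stated time of 48 h (a higher number here means a weaker inhibitor of growth, a lower number a stronger inhibitor of growth), compound 1 `N#CCC1=C(C#N)CC(c2ccc([N+](=O)[O-])cc2)=C(CC(=O)c2ccc(Br)cc2)O1` gives 3600 nM and compound 2 `N#CCC1=NN=C(c2ccc([N+](=O)[O-])cc2)CO1` gives 2 nM. Compound 3 `N#CCC1=NN=C(c2ccc(Br)cc2)C(Br)O1`, at 38200 nM, has the highest number of the three and is the weakest inhibitor of growth among them. Compound 4 `N#CCC1=NN=C(c2ccc([N+](=O)[O-])cc2)C(Br)O1` carries nitro in place of bromo on an aromatic carbon, para to a large group: nitro in place of bromo on an aromatic carbon. Going by the values given here, no measured pair isolates this change. Yet both nitro-bearing compounds lie well under compound 3, with compound 1 at 3600 nM and compound 2 at 2 nM. A large step toward stronger inhibition is therefore expected, a 130-fold lower number from compound 3 to compound 4 (2.10 log units; beyond the scatter), though compound 4 keeps a bromo that compound 2 lacks. Compound 4 is estimated at 300 nM, with an expected range of 10 nM to 8000 nM.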

Compound 4, concentration for 50% growth inhibition: 8500 nM
Compound 4: the middle estimate sits 28-fold (1.45 log units) below what was measured; the whole stated range lies below it.
By their numbers in this assay, from the lowest: compound 2; then compound 1; then compound 4; then compound 3.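

In this assay, nitro in place of bromo on an aromatic carbon, para to a large group, gives a 4.5-fold lower number from compound 3 to compound 4 (0.65 log units; beyond the scatter) and is a modest change, so nitro alone does not bring the number near that of compound 2. Bromo in place of hydrogen on a saturated ring carbon gives a 4300-fold higher number from compound 2 to compound 4 (3.63 log units; beyond the scatter) and is the large step here. Nothing measured here explains either step. The compounds shown leave open how an amine or methoxy on that aromatic carbon would compare, and whether chloro or methyl on the saturated ring carbon would also raise the number.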